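Swapping Fluoro for Cyano on a Potent p300 Inhibitor

This account rests on a few compounds, and the source may have more. Where it says the series, first, only, none or still open, it means among the compounds named here.

Compound 1, `O=C(Nc1ccc2[nH]ncc2n1)[C@H]1CCCN1C(=O)C1(c2ccc(F)cc2)CCC1`, gives 0.126 nM in an assay on isolated protein for inhibition of histone acetyltransferase p300 (Homo sapiens), with a stated time of 60 min; on this read-out lower numbers stand for stronger inhibition and higher numbers for weaker inhibition.
Compound 2, `COc1ccc(NC(=O)[C@H]2CCCN2C(=O)C2(c3ccc(Cl)cc3)CCCCC2)cc1`, gives 20 nM in this assay.

Going by the values given here, of the two numbers measured so far, compound 1 has the lower one, and its only neighbour, compound 2, sits far higher, a gap well beyond the usual scatter. Compound 2 differs from compound 1 in several places at once, so the gap between them cannot be tied to any single change.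

Compound 3, `N#Cc1ccc(C2(C(=O)N3CCC[C@@H]3C(=O)Nc3ccc4[nH]ncc4n3)CCC2)cc1`, has not yet been measured. It is compound 1 with one change: cyano in place of fluoro on an aromatic carbon, para to a large group. Among the compounds with values here, no measured pair in this set shows the effect of this change on its own, so the expectation rests only on compound 1 and the small size of the change. The step from compound 1 to compound 3 is expected to be modest, a 1.6-fold higher number from compound 1 to compound 3 (0.20 log units; within the scatter), most likely within the scatter. Compound 3 is therefore expected to give about 0.2 nM in this assay, with a range from 0.05 nM to 1 nM.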

Compound 3, half-maximal inhibitory concentration: 0.251 nM
For compound 3 the middle estimate is 1.3-fold (0.10 log units) below the measured one; measured number inside the range.
By their numbers in this assay, from the lowest: compounds 1 and 3 (each within the scatter of the next); then compound 2.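

In this assay, going from 4-fluorophenyl to 4-cyanophenyl on the shared core gives a 2.0-fold higher number from compound 1 to compound 3 (0.30 log units; within the scatter), so this single change leaves the two compounds indistinguishable on this read-out. Going by these compounds alone, this is the first direct view of this position, on an aromatic carbon para to a large group: fluoro, with 1 heavy atom and 0 hydrogen-bond acceptors, and cyano, with 2 heavy atoms and 1 hydrogen-bond acceptor, give numbers that cannot be separated. Nothing measured here explains why these two groups read alike.

A single pair says nothing about how other groups behave at this position, so an amine, a carboxylic acid or a longer chain such as n-butyl could give a very different number from the one seen with fluoro and cyano. Going by these compounds, it also remains open whether the same swap would read alike on a different core, or whether the match seen here belongs to the core of compound 1 alone.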